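The source may hold more compounds than are shown below. What is called first, only, known or untested is meant among the compounds shown, and "the series" means these compounds.

Compound 1 `CC(C)(C)OC(=O)N1CCN(C(=S)SCc2cn(C[C@H](O)[C@H]3OC(=O)C(OCc4ccccc4)=C3OCc3ccccc3)nn2)CC1` and compound 2 `COc1ccccc1-c1cn(C[C@H](O)[C@H]2OC(=O)C(OCc3ccccc3)=C2OCc2ccccc2)nn1` share one core and differ only in the group carried on the five-membered aromatic ring with three nitrogens. In a functional assay on MCF7 cells (Homo sapiens) for antiproliferative activity, read by MTT assay, with a stated time of 72 h (a higher number here means a weaker inhibitor, a lower number a stronger inhibitor), compound 1 gives no number but only a limit, > 100000 nM. In this assay compound 2 likewise gives only a limit, > 100000 nM. Within the data shown here, both readings sit at the limit of > 100000 nM in this assay, at which 2 of the 2 values shown sit, so compound 2 stands at the edge of what this assay can report, and no measured step leads to it or away from it. Compound 3 `Cc1ccc(-c2cn(C[C@H](O)[C@H]3OC(=O)C(OCc4ccccc4)=C3OCc3ccccc3)nn2)cc1` is the unmeasured partner of compound 2: the change is 4-methylphenyl in place of 2-methoxyphenyl on an aromatic carbon, in words 4-methylphenyl in place of 2-methoxyphenyl on an aromatic carbon. Among the measured compounds shown here, no measured pair shows what such a change does in this assay, so the expectation rests only on where compound 2 stands. The expected step is a step that the limit leaves unreadable from compound 2 to compound 3, none beyond the scatter. Compound 3 is therefore estimated at 150000 nM, with a range from 40000 nM to 600000 nM, and most probably reported once more only as a limit.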

Compound 3, half-maximal inhibitory concentration: > 100000 nM
Compound 3: no number, only a limit; the forecaster's own chance of this, stated with the estimate: 85%; the middle value is on the limit's open side.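

Among these compounds, no step from compound 2 to compound 3 can be read, because both results are limits and not numbers: the limit of > 100000 nM in this assay, at which 3 of the 3 values shown sit. The compounds shown leave open whether in this assay the 4-methylphenyl and 2-methoxyphenyl groups differ at all, and what activity, if any, compounds on the shared core can reach.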